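Replacing Hexyl with 3-Chlorophenyl on the Amine Nitrogen

The source may report more compounds than this note shows. Statements on the series, on what has been measured and on what is new or still open speak of the compounds shown alone.

Compound 1 `CCCCCCNc1nc(SCc2ccc(C(F)(F)F)cc2)nc2ccccc12` gives 19000 nM in a functional assay on PC-3 cells (Homo sapiens) for cytotoxicity, read by MTT assay, with a stated time of 72 h (on this read-out lower numbers stand for stronger inhibition and higher numbers for weaker inhibition), the smallest of the three numbers at hand, yet compound 2 `FC(F)(F)c1ccc(CSc2nc(Nc3ccccc3)c3ccccc3n2)cc1` at 20000 nM and compound 3 `CCOc1ccccc1Nc1nc(SCc2ccc(C(F)(F)F)cc2)nc2ccccc12` at 26200 nM both sit within the usual scatter of it. The steps of a 1.1-fold higher number from compound 1 to compound 2 (0.02 log units; within the scatter) and a 1.4-fold higher number from compound 1 to compound 3 (0.14 log units; within the scatter) are each within that scatter. Compound 4 `FC(F)(F)c1ccc(CSc2nc(Nc3cccc(Cl)c3)c3ccccc3n2)cc1` differs from compound 1 by 3-chlorophenyl in place of hexyl on a nitrogen on an aromatic ring. Among the compounds with values here, the step to compound 2 is the closest precedent, since it also swaps hexyl for an aryl group on that nitrogen, and the step of a 1.3-fold higher number from compound 2 to compound 3 (0.12 log units; within the scatter) shows a substituent on that ring changing little. Compound 4 is therefore expected to show a 1.1-fold higher number from compound 1 to compound 4 (0.04 log units; within the scatter), no step beyond the scatter. Compound 4 is estimated at 21000 nM, between 10000 nM and 42000 nM.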

Compound 4, half-maximal inhibitory concentration: 13400 nM
Beside the measured number, compound 4's estimate is 1.6-fold (0.20 log units) above it; measured number inside the range.
By their numbers in this assay, from the lowest: compounds 4, 1, 2 and 3 (each within the scatter of the next).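

In this assay, 3-chlorophenyl on this nitrogen stays within the scatter of hexyl (a 1.4-fold lower number from compound 1 to compound 4 (0.15 log units; within the scatter)) and of 2-ethoxyphenyl (a 2.0-fold lower number from compound 3 to compound 4 (0.29 log units; within the scatter)). Adding chloro to the aromatic ring also stays within the scatter (a 1.5-fold lower number from compound 2 to compound 4 (0.17 log units; within the scatter)), so the four groups at this position give numbers that cannot be told apart here. No evidence at hand bears on this result.

The compounds shown leave open whether an amine, a carboxylic acid or a chain longer than hexyl on this nitrogen would move the number beyond the scatter. Nor do they show whether a change elsewhere, such as nitrile in place of trifluoromethyl, would do so.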